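Propyl in place of acetyl on the compound 1 scaffold

A few compounds are considered here, and "the series" means these few. Any claim that something is new, unique, unknown or untested is made for them only; others in the source may bear on it.

In a functional assay on the whole organism (brain) with Mus musculus as the target (a higher number here means that more compound is needed for the effect, a lower number that less compound is needed), compound 1 `CC(=O)c1ccc(OCCc2c[nH]cn2)cc1` gives 3.2 mg/kg and compound 2 `O=C(c1ccccc1)c1ccc(OCCc2c[nH]cn2)cc1` gives 2.6 mg/kg, so the two stand within the scatter of each other. Compound 3 `CCCc1ccc(OCCc2c[nH]cn2)cc1` carries propyl in place of acetyl on an aromatic carbon. Among the measured compounds shown here, the carbonyl is thus lost, and no measured compound lacks it, so the data hold no direct precedent for this change. For the measured compounds named here, only one measured step bears on it, and only indirectly: a 1.2-fold lower number from compound 1 to compound 2 (0.09 log units; within the scatter), with phenyl in place of methyl on a carbonyl carbon. Going by the values given here, with that small step as the sole guide, no clear direction can be assigned in this assay, and no shift beyond the scatter is expected. The expected change is a 1.3-fold lower number from compound 1 to compound 3 (0.11 log units; within the scatter). Compound 3 is estimated at 2.5 mg/kg, with an expected range from 0.9 mg/kg to 7 mg/kg.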

Compound 3, dose for half-maximal effect: 1.6 mg/kg
Compound 3: the middle estimate sits 1.6-fold (0.19 log units) above what was measured; the measured number falls inside the stated range.
By their numbers in this assay, from the lowest: compounds 3, 2 and 1 (each within the scatter of the next).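

Across the exchange of acetyl for propyl on the aromatic carbon, the step in this assay is a 2.0-fold lower number from compound 1 to compound 3 (0.30 log units; within the scatter) and so does not separate the two groups. The earlier pair varied only the group on the carbonyl carbon, whereas this result shows that the effect in the whole animal persists with the carbonyl and its hydrogen-bond acceptor gone, at the site para to a group of 8 heavy atoms. No measurement at hand accounts for this result.

Every step shown at this position remains within the scatter, so no group here is yet set apart from another in this assay. From the compounds shown here alone, whether an amine, a carboxylic acid or a longer chain such as hexyl on this aromatic carbon would shift the number beyond the scatter remains open.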